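A few compounds are considered here, and "the series" means these few. Any claim that something is new, unique, unknown or untested is made for them only; others in the source may bear on it.

Compound 1 `NC(=O)/C=C/c1ccncc1-c1ccc2ccccc2c1` is recorded in a functional assay on KB cells (Homo sapiens) for inhibition, read by sulforhodamine B assay, with a stated time of 72 h (a higher number here means a weaker inhibitor of growth, a lower number a stronger inhibitor of growth), only as the limit > 10000 nM.
Compound 2 `COC1CN(C(=O)/C=C/c2ccncc2-c2ccc3ccccc3c2)C1` is likewise recorded in this assay only as the limit > 10000 nM.
Compound 3 `CNC(=O)CCc1ccncc1-c1ccc2ccccc2c1` is also recorded in this assay only as the limit > 10000 nM.

Compound 3 thus stands nowhere that can be ranked: all three measured compounds sit at the same limit, as the limit of > 10000 nM in this assay, at which 3 of the 3 values shown sit, shows, and no one of them can be called more or less active than another. Among the measured compounds shown here, the two measured steps, a step that the two limits leave unreadable from compound 1 to compound 2 and a step that the two limits leave unreadable from compound 1 to compound 3, are for this reason unreadable in size and direction; they say only that neither the change at the carbonyl carbon nor the change on the aromatic carbon brought growth inhibition into the measurable range.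

Compound 4 `O=C(O)CCc1ccncc1-c1ccc2ccccc2c1` differs from compound 3 in the following way: hydroxy in place of methylamino on a carbonyl carbon. For the measured compounds named here, no measured step speaks to this change, so the expectation rests on the shared core and the fact that every measured analogue, including compound 3 with > 10000 nM, reached only a limit. The step that the limit leaves unreadable from compound 3 to compound 4 is therefore expected to be essentially none, with the most likely outcome again a limit. Compound 4 is estimated at 15000 nM, with a range from 5000 nM to 50000 nM.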

Compound 4, concentration for 50% growth inhibition: > 10000 nM
Compound 4 gave a limit, no number; the forecaster's own chance of this, stated with the estimate: 85%; the middle value does not contradict the limit.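

Compound 4 sits at a limit in this assay, as compound 1, compound 2 and compound 3 do, so neither of its steps, from compound 3 or from compound 1, can be read: the limit of > 10000 nM in this assay, at which 4 of the 4 values shown sit.

The compounds shown leave open which change to the shared core, if any, would bring growth inhibition into the measurable range in this assay.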